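A few compounds are considered here, and "the series" means these few. Any claim that something is new, unique, unknown or untested is made for them only; others in the source may bear on it.

Measured compounds:
- compound 1, `O=C(N/N=C/c1ccc(F)cc1)Nc1cc2c(Nc3ccc(F)c(Cl)c3)ncnc2cc1O[C@H]1CCOC1`: "not active" (no number reported)
- compound 2, `CC(C)(C)c1cc(/C=N/NC(=O)Nc2cc3c(Nc4ccc(F)c(Cl)c4)ncnc3cc2O[C@H]2CCOC2)cc(C(C)(C)C)c1O`: 12500 nM
- compound 3, `COc1cc2ncnc(Nc3ccc(F)c(Cl)c3)c2cc1NC(=O)N/N=C/c1ccc(F)cc1`: 31100 nM

In a functional assay on HepG2 cells (Homo sapiens) for cytotoxicity, read by MTT assay, with a stated time of 72 h (a lower number here means a stronger inhibitor, a higher number a weaker inhibitor), compound 1, `O=C(N/N=C/c1ccc(F)cc1)Nc1cc2c(Nc3ccc(F)c(Cl)c3)ncnc2cc1O[C@H]1CCOC1`, gives "not active" (no number reported), with no number reported. Compound 2, `CC(C)(C)c1cc(/C=N/NC(=O)Nc2cc3c(Nc4ccc(F)c(Cl)c4)ncnc3cc2O[C@H]2CCOC2)cc(C(C)(C)C)c1O`, gives 12500 nM in this assay. Compound 3, `COc1cc2ncnc(Nc3ccc(F)c(Cl)c3)c2cc1NC(=O)N/N=C/c1ccc(F)cc1`, gives 31100 nM in this assay, the highest of the two numbers shown; the nearest, compound 2, sits at a lower number by a gap that is beyond the usual scatter. Among the compounds with values here, compound 3 is thus the weaker of the two compounds with a number, and no step between single-change pairs is available among the measured compounds.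

Compound 4, `COc1cc2ncnc(Nc3ccc(F)c(Cl)c3)c2cc1NC(=O)N/N=C/c1ccc(O)cc1O`, is not yet measured. It differs from compound 3 in one place: 2,4-dihydroxyphenyl in place of 4-fluorophenyl on a carbon with a double bond to nitrogen. Within the data shown here, no measured pair shows the effect of such a change, so there is no step on which to rest a direction. The expectation for compound 4 is therefore a step from compound 3 of a 1.2-fold lower number from compound 3 to compound 4 (0.09 log units; within the scatter), that is, none beyond the scatter, with some chance that the readout again falls outside the measurable window. In this assay compound 4 is estimated at 25000 nM, with a range from 8000 nM to 80000 nM.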

Compound 4, half-maximal inhibitory concentration: 32100 nM
For compound 4 the middle estimate is 1.3-fold (0.11 log units) below the measured one, and the stated range covers the measured number.
By their numbers in this assay, from the lowest: compound 2; then compounds 3 and 4 (each within the scatter of the next).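

In this assay, within the data shown here, the step of a 1.0-fold higher number from compound 3 to compound 4 (0.01 log units; within the scatter) gives the first reading of a single change, made on a carbon with a double bond to nitrogen, where 2,4-dihydroxyphenyl stands in place of 4-fluorophenyl. The earlier compounds shown here offered no such pair, so nothing could be said about this position; now it can be said that this one exchange leaves the reading within the scatter. The exchange brings in the hydrogen-bond donors and acceptors counted for 2,4-dihydroxyphenyl, where 4-fluorophenyl has none, and no separation appears in this assay, though nothing at hand accounts for that result.

Going by these compounds, it stays open whether an aminophenyl group, a benzoic acid carrying a carboxylic acid, or a saturated ring such as cyclohexyl at the same place would shift the number beyond the scatter. On these data alone, it also stays open whether the same exchange would read alike on the core of compound 1, which carries a different ether on the shared core.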